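A few compounds are considered here, and "the series" means these few. Any claim that something is new, unique, unknown or untested is made for them only; others in the source may bear on it.

Working notes on the series. Three measured members share one core and differ only in the substitution pattern of the outer aryl ring of the thiourea: compound 1 `CNC(=O)c1ccc(Oc2cccc(NC(=S)Nc3ccc(F)cc3)c2)nc1`, compound 2 `CNC(=O)c1ccc(Oc2cccc(NC(=S)Nc3ccc(F)c(C(F)(F)F)c3)c2)nc1` and compound 3 `CNC(=O)c1ccc(Oc2cccc(NC(=S)Nc3ccc(F)c(Cl)c3)c2)nc1`. In a functional assay on MDA-MB-231 cells (Homo sapiens) for antiproliferative activity, read by MTT assay (a higher number here means a weaker inhibitor, a lower number a stronger inhibitor), compound 1 gives 21700 nM. In this assay compound 2 gives 13300 nM. In this assay compound 3 gives 28600 nM. Compound 2 has the lowest of the three numbers, yet the step of a 1.6-fold lower number from compound 1 to compound 2 (0.21 log units; within the scatter) is inside the scatter; only the gap to compound 3, a 2.2-fold higher number from compound 2 to compound 3 (0.33 log units; beyond the scatter), exceeds it, and the remaining step, a 1.3-fold higher number from compound 1 to compound 3 (0.12 log units; within the scatter), is also inside the scatter. Compound 4 `CNC(=O)c1ccc(Oc2cccc(NC(=S)Nc3ccc(Cl)c(C(F)(F)F)c3)c2)nc1` differs from compound 2 in one place: chloro in place of fluoro on an aromatic carbon. For the measured compounds named here, no measured step exchanges these two halogens; the three measured steps add trifluoromethyl, add chloro, or replace trifluoromethyl by chloro, and all are small. Compound 4 is therefore expected to show a 1.1-fold lower number from compound 2 to compound 4 (0.04 log units; within the scatter), nothing beyond the scatter. Compound 4 is estimated in this assay at 12000 nM, with a range from 5000 nM to 30000 nM.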

Compound 4, half-maximal inhibitory concentration: 2330 nM
Estimate against measurement, compound 4: 5.2-fold (0.71 log units) above, outside the stated range (below it).
By their numbers in this assay, from the lowest: compound 4; then compounds 2, 1 and 3 (each within the scatter of the next, the first and the last beyond it).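

In this assay, a 5.7-fold lower number from compound 2 to compound 4 (0.76 log units; beyond the scatter), so the halogen on this aromatic carbon, ortho to a trifluoromethyl group and para to a large group, is a place where a single atom exchange moves the number beyond the scatter. The earlier steps shown here all kept the fluoro in place and changed a different aromatic carbon, so they said nothing about this position, and none of them was as large as this step. Nothing at hand explains the size of this step.

Whether the step depends on the trifluoromethyl group stays open, since the compounds shown exchange fluoro for chloro only with that group present. From the compounds shown here alone, how bromo, methyl or a methoxy group would read at this same carbon also stays open.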